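Swapping tert-butyl for ethylamino on a carbonyl carbon

A few compounds are considered here, and "the series" means these few. Any claim that something is new, unique, unknown or untested is made for them only; others in the source may bear on it.

Measured in an ADME assay on HEK-293T cells (Homo sapiens) for cytotoxicity, read by MTT assay, with a stated time of 72 h (a lower number here means a stronger inhibitor, a higher number a weaker inhibitor), are these compounds
- compound 1 `CC[C@H](CO)NC(=O)C(C)(C)C` gives "not determined" (no result reported)
- compound 2 `CC[C@H](CO)NS(=O)(=O)c1ccc(NC(C)=O)cc1` gives "not determined" (no result reported)
- compound 3 `CC[C@H](CO)NC(=O)/C=C/c1ccccc1` gives 211000 nM

No single number stands for compound 1 in this assay and, among the three measured compounds, the same is true of compound 2. Compound 4 `CCNC(=O)N[C@H](CC)CO` carries ethylamino in place of tert-butyl on a carbonyl carbon. With no number for compound 1, the size of this step cannot be read from the data, but no shift beyond the usual scatter is expected in either direction. The only anchor for the expectation is compound 3 (211000 nM). For compound 4 the expected value is 300000 nM (estimated range 100000 nM to 900000 nM).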

Compound 4, half-maximal inhibitory concentration: 114000 nM
Estimate against measurement, compound 4: 2.6-fold (0.42 log units) above; measured number inside the range.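

In this assay, among the compounds shown here, compound 1 has no single number, so no step to compound 4 can be read. The compounds shown leave open what swapping tert-butyl for ethylamino does to this read-out. No evidence bears on the result.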